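This account rests on a few compounds, and the source may have more. Where it says the series, first, only, none or still open, it means among the compounds named here.

Measured in a functional assay on PC-3 cells (Homo sapiens) for cytotoxicity, read by MTT assay, with a stated time of 72 h; a higher number here means a weaker inhibitor, a lower number a stronger inhibitor:
- Compound 1 `COc1cc(/C=C/C(=O)/C(=C/c2ccc3ccccc3n2)C(=O)/C=C/C2=C(C)CCCC2(C)C)ccc1O`: 15200 nM
- Compound 2 `COc1cc(/C=C/C(O)=C/C(=O)/C=C/C2=C(C)CCCC2(C)C)cc(OC)c1O`: 26700 nM

Compound 1, at 15200 nM, lies within the usual scatter of compound 2, so the two numbers cannot be told apart. Compound 3 `COc1cc(/C=C(\C(=O)/C=C/C2=C(C)CCCC2(C)C)C(=O)/C=C/c2ccc(O)c(OC)c2)ccc1O` has not yet been measured. It carries 4-hydroxy-3-methoxyphenyl in place of quinolin-2-yl on a double-bonded chain carbon bound to a double-bonded chain carbon. Within the data shown here, no measured step covers this change, so no shift beyond the scatter is expected in this assay, in either direction. The estimated change is a 1.1-fold lower number from compound 1 to compound 3 (0.04 log units; within the scatter). For compound 3 the expected value is 14000 nM, within an estimated range of 5000 nM to 35000 nM.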

Compound 3, half-maximal inhibitory concentration: 4200 nM
Beside the measured number, compound 3's estimate is 3.3-fold (0.52 log units) above it, outside the stated range (below it).
By their numbers in this assay, from the lowest: compound 3; then compounds 1 and 2 (each within the scatter of the next).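

In this assay, the substituent on a double-bonded chain carbon bound to a double-bonded chain carbon is shown to matter: 4-hydroxy-3-methoxyphenyl in place of quinolin-2-yl gives a 3.6-fold lower number from compound 1 to compound 3 (0.56 log units; beyond the scatter), a modest step beyond the scatter. The two earlier compounds, which differ in more than one place, could not show this. No supporting data are available to explain the shift.

On these data alone, it remains open whether the hydroxyl, the methoxy or the loss of the quinoline ring system accounts for the step. A plain phenyl or a 4-aminophenyl group at this position would help separate these possibilities.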